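This account rests on a few compounds, and the source may have more. Where it says the series, first, only, none or still open, it means among the compounds named here.

Among the compounds with values here, in a functional assay on A549/CDDP cells (Homo sapiens) for antiproliferative activity, read by MTT assay, with a stated time of 72 h (a higher number here means a weaker inhibitor, a lower number a stronger inhibitor), compound 3 `Cc1nc(C)c(/C=C/C(=O)/C=C/c2ccccc2)nc1C` gives 11900 nM, the highest number of the three measured so far, which makes it the weakest of them. Compound 1 `Cc1nc(C)c(/C=C/C(=O)/C=C/c2cccc(O)c2)nc1C` gives 3700 nM and compound 2 `COc1cccc(/C=C/C(=O)/C=C/c2nc(C)c(C)nc2C)c1` gives 3440 nM, and these two do not truly differ: a 1.1-fold lower number from compound 1 to compound 2 (0.03 log units; within the scatter).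

Compound 4 `Cc1nc(C)c(/C=C/C(=O)/C=C/c2cccc([N+](=O)[O-])c2)nc1C` changes compound 3 in one place: nitro in place of hydrogen on an aromatic carbon. Nitro replaces hydrogen on an aromatic carbon, meta to a large group. Within the data shown here, two measured steps bear on this, both swapping a group on an aromatic carbon for hydrogen. Hydrogen in place of hydroxy gave a 3.2-fold higher number from compound 1 to compound 3 (0.51 log units; beyond the scatter), and hydrogen in place of methoxy gave a 3.5-fold higher number from compound 2 to compound 3 (0.54 log units; beyond the scatter). Both are modest, and read in reverse they show that adding either group to compound 3 lowers the number. Among the measured compounds shown here, no measured compound carries nitro, so this is only a loose guide. A modest fall in this assay is therefore expected, with the estimated step being a 2.4-fold lower number from compound 3 to compound 4 (0.38 log units; beyond the scatter). For compound 4 the estimate is 5000 nM, with an expected range of 1800 nM to 13000 nM.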

Compound 4, half-maximal inhibitory concentration: 6690 nM
Compound 4: the middle estimate sits 1.3-fold (0.13 log units) below what was measured; measured number inside the range.
By their numbers in this assay, from the lowest: compounds 2, 1, 4 and 3 (each within the scatter of the next, the first and the last beyond it).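

In this assay nitro on this aromatic carbon, meta to a large group, gives a 1.8-fold lower number from compound 3 to compound 4 (0.25 log units; within the scatter) and so cannot be told apart from plain hydrogen, whereas hydroxy and methoxy in this place both stood clear of hydrogen. Nitro cannot be told apart from those two groups either: nitro in place of methoxy gives a 1.9-fold higher number from compound 2 to compound 4 (0.29 log units; within the scatter) and nitro in place of hydroxy gives a 1.8-fold higher number from compound 1 to compound 4 (0.26 log units; within the scatter) and thus compound 4 lies within the scatter of all three neighbours, though compound 3 and the pair of compound 1 and compound 2 do differ. Nothing measured here explains this result.

Going by these compounds, whether an amine or a carboxylic acid on this carbon would fall with hydrogen or with hydroxy and methoxy stays open. So does what any of these groups would do on the other carbons of this ring.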